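A few compounds are considered here, and "the series" means these few. Any claim that something is new, unique, unknown or untested is made for them only; others in the source may bear on it.

Compound 1 `Cc1nnc(N2CCC(C(=O)N3N=CC[C@H]3c3ccccc3)CC2)o1` at 18 mL/min/kg
Compound 2 `O=C(c1cn[nH]c1)N1CCC(C(=O)N2N=CCC2c2ccccc2)CC1` at 46 mL/min/kg

Among the compounds with values here, in an ADME assay on the whole organism (Rattus norvegicus) for pharmacokinetics, at a dose of 1 mg/kg by the intravenous route (a lower number here means slower removal, a higher number faster removal of the compound), only these two compounds have numbers so far. Compound 2 stands highest of the two at 46 mL/min/kg on this read-out, and the gap down to compound 1 lies beyond the scatter. Compound 3 `O=C(c1c[nH]nn1)N1CCC(C(=O)N2N=CCC2c2ccccc2)CC1` is still unmeasured. It carries 1H-1,2,3-triazol-4-yl in place of 1H-pyrazol-4-yl on a carbonyl carbon, and the count for this swap reads 1H-1,2,3-triazol-4-yl in place of 1H-pyrazol-4-yl on a carbonyl carbon in full. Within the data shown here, no measured pair shows this change, so the expectation rests on compound 2 at 46 mL/min/kg alone: a small downward move, nothing beyond the scatter. The expected step is a 1.2-fold lower number from compound 2 to compound 3 (0.08 log units; within the scatter) in this estimate. For compound 3 the estimated clearance is 38 mL/min/kg with an expected range from 19 mL/min/kg to 75 mL/min/kg once it is measured in this assay as well.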

Compound 3, clearance: 37 mL/min/kg
Compound 3: the middle estimate sits 1.0-fold (0.01 log units) above what was measured; the measured number falls inside the stated range.
By their numbers in this assay, from the lowest: compound 1; then compounds 3 and 2 (each within the scatter of the next).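

In this assay, placing 1H-1,2,3-triazol-4-yl in place of 1H-pyrazol-4-yl on a carbonyl carbon gives a 1.2-fold lower number from compound 2 to compound 3 (0.09 log units; within the scatter) as the result. Within the data shown here, this pair is the first to differ in one place, and it shows that at this position, going from a ring with 2 hetero atoms to one with 3 hetero atoms, and from 1 hydrogen-bond acceptor to 2, does not carry the read-out outside the scatter. Nothing on hand says why the two compounds read so closely.

Compound 1 differs from compound 2 and compound 3 in more than one place, so no single group can be held to account for its value. On these data alone, whether a tetrazole, a carboxylic acid or a simple amine on that carbonyl carbon would shift the clearance beyond the scatter remains open.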